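Adding a methyl to the urea phenyl of compound 2

The source may report more compounds than this note shows. Statements on the series, on what has been measured and on what is new or still open speak of the compounds shown alone.

Of the compounds shown here, two have been measured in a functional assay on MDA-MB-231 cells (Homo sapiens) for cytotoxicity, read by MTT assay, with a stated time of 72 h; a higher number here means a weaker inhibitor, a lower number a stronger inhibitor. Compound 1, with the structure `CN(C)CCCNc1nc(-c2ccc(NC(=O)Nc3ccc(F)cc3)cc2)nc2c(Cl)c(Cl)sc12`, gives 980 nM. Compound 2, with the structure `CN(C)CCNc1nc(-c2ccc(NC(=O)Nc3ccccc3)cc2)nc2ccsc12`, gives 1310 nM in this assay. The two numbers lie within the scatter of each other, so no difference beyond the usual noise of repeated measurements separates compound 2 from compound 1; the two structures also differ in several places at once, so nothing can be read from the pair about any single change.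

Compound 3, with the structure `Cc1ccc(NC(=O)Nc2ccc(-c3nc(NCCN(C)C)c4sccc4n3)cc2)cc1`, has not yet been measured in this assay. It differs from compound 2 in one place: methyl in place of hydrogen on an aromatic carbon, on the phenyl ring at the far end of the urea. For the measured compounds named here, with no measured pair that isolates this change, the expectation can rest only on the modest size of the group added. The step from compound 2 to compound 3 is therefore expected to be small, a 1.1-fold lower number from compound 2 to compound 3 (0.04 log units; within the scatter), and not beyond the scatter in either direction. Compound 3 is estimated to give 1200 nM in this assay, within a range from 500 nM to 2800 nM.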

Compound 3, half-maximal inhibitory concentration: 2180 nM
For compound 3 the middle estimate is 1.8-fold (0.26 log units) below the measured one; low and high end bracket the measured number.
By their numbers in this assay, from the lowest: compounds 1, 2 and 3 (each within the scatter of the next, the first and the last beyond it).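

For the compounds shown here, compound 2 and compound 3 form the first pair here that differs in only one place, so a single change can finally be read in this assay: methyl in place of hydrogen on an aromatic carbon, para to a large group, gives a 1.7-fold higher number from compound 2 to compound 3 (0.22 log units; within the scatter). At this position, then, going from phenyl to 4-methylphenyl, with one added carbon, produces no difference that can be told apart from the ordinary noise of repeated measurements, so this single pair gives no sign that the position responds to a methyl group. No supporting information bears on this result, and one pair with a step this small offers nothing to interpret further.

On these data alone, it remains open whether a larger or very different group at the same place, such as tert-butyl, methoxy, an amine or a carboxylic acid, would give a step beyond the scatter. Compound 1 carries a fluorine on this ring, but it also differs from compound 2 elsewhere, so the effect of fluorine alone cannot be read from these compounds.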